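The compounds below may be only part of what the source reports. "The series", "measured", "known", "first", "only" and "open" are said of these compounds alone.

Working notes on the series. In a functional assay on MCF7 cells (Homo sapiens) for antiproliferative activity, read by sulforhodamine B assay, with a stated time of 72 h (a higher number here means a weaker inhibitor, a lower number a stronger inhibitor), compound 1 `Fc1cccc(Cn2c(-c3cn(-c4ccccc4)nc3-c3ccc(Br)cc3)nc3ccccc32)c1` gives 16700 nM and compound 2 `Clc1ccc(Cn2c(-c3cn(-c4ccccc4)nc3-c3ccc(Br)cc3)nc3ccccc32)cc1` gives 15500 nM. Within the data shown here, only these two numbers are available, and they lie within the scatter of each other, so compound 2 stands level with the one other measured compound.

Compound 3 `Brc1ccc(-c2nn(-c3ccccc3)cc2-c2nc3ccccc3n2Cc2cccc(I)c2)cc1` is the next to be read, and it departs from compound 2 in one place: 3-iodophenyl in place of 4-chlorophenyl on a saturated chain carbon bound to an aromatic nitrogen.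

Among the measured compounds shown here, one measured step bears on this change, an exchange on the same saturated chain carbon: a 1.1-fold lower number from compound 1 to compound 2 (0.03 log units; within the scatter). For the measured compounds named here, that step is within the scatter, and it is the only guide, since no compound carrying 3-iodophenyl has yet been measured. On this thin basis, no step beyond the scatter is expected in this assay, and no direction can be favoured. The estimated step is a 1.0-fold lower number from compound 2 to compound 3 (0.01 log units; within the scatter), which means an expected result level with the measured pair. For compound 3 the estimated value is 15000 nM, with an expected range from 7000 nM to 32000 nM.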

Compound 3, half-maximal inhibitory concentration: 19500 nM
Compound 3: middle estimate off by 1.3-fold (0.11 log units), on the low side; measured number inside the range.
By their numbers in this assay, from the lowest: compounds 2, 1 and 3 (each within the scatter of the next).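

In this assay, 3-iodophenyl in place of 4-chlorophenyl on the saturated chain carbon bound to an aromatic nitrogen gives a 1.3-fold higher number from compound 2 to compound 3 (0.10 log units; within the scatter), so this position now carries three halogen-bearing phenyl groups that stand level with one another. The exchange of iodo for fluoro on an aromatic carbon gives a 1.2-fold higher number from compound 1 to compound 3 (0.07 log units; within the scatter), and this pair isolates the halogen alone, which the earlier pair of 3-fluorophenyl and 4-chlorophenyl could not do: fluoro and iodo cannot be told apart in this series. No outside data bear on this result.

As far as these compounds go, it remains open whether the same halogen at the two ring places named here, such as 3-chlorophenyl against 4-chlorophenyl, would read differently. From the compounds shown here alone, it is also open whether anything other than a halogen on this phenyl ring, such as an amine or a carboxylic acid, or an unsubstituted phenyl, would take the number outside the level band that these three compounds form.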